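Notes on the aryl change from compound 3 to compound 4

This account rests on a few compounds, and the source may have more. Where it says the series, first, only, none or still open, it means among the compounds named here.

The three measured compounds share one core and differ in the group carried on a nitrogen on an aromatic ring and in the group attached through sulfur. Compound 1 `C#CCSc1nc(Nc2ccc(OC)cc2)c(C#N)c(-c2ccccc2)n1` gives 9710 nM in a functional assay on B16-F10 cells (Mus musculus) for inhibition, read by MTT assay, with a stated time of 72 h; a lower number here means a stronger inhibitor, a higher number a weaker inhibitor. Compound 2 `C#CCSc1nc(Nc2ccccc2Cl)c(C#N)c(-c2ccccc2)n1` gives 12400 nM in this assay. Compound 3 `N#Cc1c(Nc2ccccc2Cl)nc(SCc2cn(Cc3ccccc3Cl)nn2)nc1-c1ccccc1` gives 8350 nM in this assay, the lowest of the three numbers, though its gaps to compound 1 and to compound 2 both lie within the scatter, so no order among the three can be read.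

Compound 4 `N#Cc1c(Nc2cccc([N+](=O)[O-])c2)nc(SCc2cn(Cc3ccccc3Cl)nn2)nc1-c1ccccc1` is not yet measured. It differs from compound 3 by 3-nitrophenyl in place of 2-chlorophenyl on a nitrogen on an aromatic ring. Going by the values given here, the only measured step that touches this position is a 1.3-fold higher number from compound 1 to compound 2 (0.11 log units; within the scatter), a change within the scatter. That step exchanged one group for another on the same nitrogen, as here, without a shift beyond noise; nothing measured bears on the 3-nitrophenyl group itself. The expected step is therefore a 1.0-fold lower number from compound 3 to compound 4 (0.02 log units; within the scatter), none beyond the scatter. Compound 4 is expected to give 8000 nM in this assay, with a range of 3500 nM to 18000 nM.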

Compound 4, half-maximal inhibitory concentration: 17200 nM
Compound 4: middle estimate off by 2.2-fold (0.33 log units), on the low side, and the stated range covers the measured number.
By their numbers in this assay, from the lowest: compounds 3, 1, 2 and 4 (each within the scatter of the next, the first and the last beyond it).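

Going by these compounds alone, on the nitrogen on an aromatic ring, the exchange of 2-chlorophenyl for 3-nitrophenyl gives the first step at this position that passes the scatter: in this assay it is a 2.1-fold higher number from compound 3 to compound 4 (0.31 log units; beyond the scatter) and is modest in size, whereas a 1.3-fold higher number from compound 1 to compound 2 (0.11 log units; within the scatter) stayed within it. The position is therefore not indifferent to every aryl exchange, though this rests on one pair, with the group attached through sulfur held as in compound 3. Nothing available explains the shift.

The change alters both the substituent and its place on the phenyl ring, so the compounds shown do not separate the nitro group from its placement. Also open, going by these compounds, are how an amine or a carboxylic acid in place of the nitro group would read, and whether the step recurs with the sulfur group of compound 2.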